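This account rests on a few compounds, and the source may have more. Where it says the series, first, only, none or still open, it means among the compounds named here.

Measured in a physicochemical assay for lipophilicity, at pH 7.4; on this read-out higher numbers stand for higher lipophilicity and lower numbers for lower lipophilicity:
- compound 1 (`CNC(=O)c1cc(C(=O)N[C@H]2CC[C@H](O)CC2)cc2c1OC[C@@]2(C)c1ccccc1`): 3.3
- compound 2 (`CNC(=O)c1cc(C(N)=O)cc2c1OC[C@H]2c1ccccc1`): 2.7
- compound 3 (`CNC(=O)c1cc(C(=O)N[C@@H]2C[C@H]2C)cc2c1O[C@H](CF)[C@H]2c1ccccc1`): 4.5

Compound 1 stands in the middle of these three numbers, beyond the scatter from both of the others: compound 2 lies lower and compound 3 lies higher. Compound 4 (`CNC(=O)c1cc(C(=O)NC)c2c(c1)[C@](C)(c1ccccc1)CO2`) has not yet been measured in this assay. It departs from compound 1 in one place: methyl in place of 4-hydroxycyclohexyl on an amide-type nitrogen, which is methyl in place of 4-hydroxycyclohexyl on an amide-type nitrogen. Among the compounds with values here, no measured pair isolates this change, so the expectation rests on thin evidence. Compound 2, with only hydrogens on the corresponding amide-type nitrogen, gives 2.7, but it also differs from compound 1 elsewhere in the structure. On this basis, a slight fall that stays within the scatter is expected, an estimated a number 0.20 log units lower from compound 1 to compound 4 (within the scatter). Compound 4 is estimated at 3.1, with an expected range of 2.6 to 3.6.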

Compound 4, distribution coefficient: 3.4
Estimate against measurement, compound 4: 0.30 log units below, and the stated range covers the measured number.
By their numbers in this assay, from the lowest: compound 2; then compounds 1 and 4 (each within the scatter of the next); then compound 3.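

In this assay, within the data shown here, the exchange of 4-hydroxycyclohexyl for methyl on the amide-type nitrogen gives a number 0.10 log units higher from compound 1 to compound 4 (within the scatter), the first step in which this position is read on its own. On the core of compound 1, then, the departure of the whole group, including its six-membered non-aromatic ring of carbon only and its hydrogen-bond donor and acceptor, cannot be told from the scatter of this read-out. Nothing available gives a reason for this result.

The compounds shown leave open whether the same holds for other groups on this nitrogen, such as plain cyclohexyl, a longer chain, or a group carrying an amine or a carboxylic acid. They also leave open whether this step would hold on the cores of compound 2 and compound 3.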